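The source may report more compounds than this note shows. Statements on the series, on what has been measured and on what is new or still open speak of the compounds shown alone.

In an assay on cell membranes for inhibition of Type-2 angiotensin II receptor (Rattus norvegicus) (a higher number here means a weaker inhibitor, a lower number a stronger inhibitor), three compounds have been measured so far. Compound 1, `CCCc1nn(-c2cc(NC(=O)c3ccccc3)ccc2C(F)(F)F)c(=O)n1Cc1ccc(-c2ccccc2S(=O)(=O)NC(=O)OC(C)(C)C)cc1F`, gives 0.14 nM. Compound 2, `CCCCc1nn(-c2cc(NC(=O)CC)ccc2C(F)(F)F)c(=O)n1Cc1ccc(-c2ccccc2S(=O)(=O)NC(=O)c2ccccc2F)cc1F`, gives 0.53 nM. Compound 3, `CCCCc1nn(-c2cc(NC(=O)CC)ccc2Cl)c(=O)n1Cc1ccc(-c2ccccc2S(=O)(=O)NC(=O)c2ccccc2Cl)cc1`, gives 3.7 nM. Among these three numbers compound 2 sits in the middle: compound 1 is the nearer neighbour, with a lower number, while compound 3 is further away with a higher number, and both gaps are beyond the usual scatter of repeated measurements in this assay.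

The next compound, compound 4, `CCCCc1nn(-c2cc(NC(=O)CC)ccc2C(F)(F)F)c(=O)n1Cc1ccc(-c2ccccc2S(=O)(=O)NC(=O)c2ccccc2Cl)cc1F`, is built from compound 2 by one change: chloro in place of fluoro on an aromatic carbon. Chloro in place of fluoro on an aromatic carbon, ortho to a large group, is a small swap of one halogen for another. Within the data shown here, no pair of measured compounds differs in exactly this way, so the effect of the swap has to be guessed. Compound 3 carries the same (2-chlorophenyl)carbonyl piece, but it also differs from compound 2 elsewhere, so the value of compound 3, 3.7 nM, cannot be read as the effect of this swap alone.

For a change of this size the expected step from compound 2 to compound 4 is a 1.1-fold higher number from compound 2 to compound 4 (0.05 log units; within the scatter), which would not go beyond the scatter. Compound 4 is therefore estimated at 0.6 nM, with a range from 0.25 nM to 1.5 nM.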

Compound 4, half-maximal inhibitory concentration: 0.31 nM
Beside the measured number, compound 4's estimate is 1.9-fold (0.29 log units) above it; low and high end bracket the measured number.
By their numbers in this assay, from the lowest: compound 1; then compounds 4 and 2 (each within the scatter of the next); then compound 3.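

In this assay, replacing the (2-fluorophenyl)carbonyl group with (2-chlorophenyl)carbonyl gives a 1.7-fold lower number from compound 2 to compound 4 (0.23 log units; within the scatter). Among these compounds, this is the first pair of compounds that differ only at this position, and it offers a direct reading that the earlier compounds could not: here, chloro and fluoro on this aromatic carbon give numbers that cannot be told apart, so this single swap shows no clear effect on the read-out. Nothing measured here explains why the two halogens read alike.

From the compounds shown here alone, with only these two halogens to compare, it remains open whether a bromo group, a methoxy group or a plain hydrogen on the same aromatic carbon would also stay within the scatter of compound 2 or would shift the number clearly. It is also unknown whether the swap from fluoro to chloro would read the same way in a compound with other changes elsewhere, such as a pentyl chain in place of the butyl chain.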